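Swapping the Amide Amine on a Melanocortin Agonist Core

The source may report more compounds than this note shows. Statements on the series, on what has been measured and on what is new or still open speak of the compounds shown alone.

Compound 1 `O=C1C(Cc2n[nH]c3cc(F)ccc23)C(=O)N(c2ccccc2)C=CN1CC(=O)N1CCCCc2ccccc21` and compound 2 `O=C1C(Cc2n[nH]c3ccccc23)C(=O)N(c2ccccc2)C=CN1CC(=O)N1CCCCc2ccccc21` share one core and differ only by hydrogen in place of fluoro on an aromatic carbon. In a functional assay on CHO cells for agonist activity at Melanocyte-stimulating hormone receptor (Homo sapiens), read by a luciferase reporter, with a stated time of 4 h (a higher number here means that more compound is needed for the effect, a lower number that less compound is needed), compound 1 gives 1.59 nM, and compound 2 gives 1.59 nM; the step of no change at the digits printed from compound 1 to compound 2 (within the scatter) shows that this swap leaves the read-out where it was, so compound 1 stands level with compound 2.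

Compound 3 `CC(C)N(C(=O)CN1C=CN(c2ccccc2)C(=O)C(Cc2n[nH]c3cc(F)ccc23)C1=O)c1ccc(F)cc1` has not yet been measured. It keeps the fluoro of compound 1 and changes elsewhere: a group of 11 heavy atoms (9 carbon, 1 nitrogen, 1 fluorine; one six-membered aromatic ring of carbon only) in place of a group of 11 heavy atoms (10 carbon, 1 nitrogen; one six-membered aromatic ring of carbon only, one seven-membered non-aromatic ring with 1 hetero atom), on a carbonyl carbon, on a carbonyl carbon. Among the compounds with values here, no measured step touches this part of the molecule, so nothing here tells how large the effect will be; the only guide is that the core tolerates a small change at the aromatic carbon without loss. A modest rise in the half-maximal effective concentration is expected, with wide uncertainty. Compound 3 is estimated at 5 nM, with a range from 1 nM to 30 nM. That corresponds to an expected step of a 3.1-fold higher number from compound 1 to compound 3 (0.50 log units; beyond the scatter).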

Compound 3, half-maximal effective concentration: 14.1 nM
For compound 3 the middle estimate is 2.8-fold (0.45 log units) below the measured one; measured number inside the range.
By their numbers in this assay, from the lowest: compounds 1 and 2 (each within the scatter of the next); then compound 3.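

Unlike the swap of fluoro for hydrogen on the aromatic carbon, the group on this carbonyl carbon does move the read-out: in this assay the change gives an 8.9-fold higher number from compound 1 to compound 3 (0.95 log units; beyond the scatter) as the result. The effect is weakened but not lost, since compound 3 still gives 14.1 nM and so keeps agonist activity with the group holding only a six-membered aromatic ring in place of the group that also holds a seven-membered non-aromatic ring. Nothing available explains why this exchange raises the number.

The compounds shown leave open which part of the entering group accounts for the step, such as its fluorine or its open chain, and how other amines, such as morpholine or piperidine, would fare on this carbonyl carbon. They also leave open whether hydrogen in place of fluoro on the aromatic carbon would stay without effect alongside this new group.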